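From an ethyl to a propyl chain on compound 3

The source may report more compounds than this note shows. Statements on the series, on what has been measured and on what is new or still open speak of the compounds shown alone.

In a functional assay on cells (Homo sapiens) for antiproliferative activity, read by MTT assay, with a stated time of 48 h (on this read-out lower numbers stand for stronger inhibition and higher numbers for weaker inhibition), compound 1 `Cn1c(N)c(-c2nc3ccccc3[nH]2)c2nc(C#N)c(C#N)nc21` gives > 50000 nM, which is a limit of the assay and not a number. Compound 2 `N#Cc1nc2c(-c3nc4ccccc4[nH]3)c(N)n(CCN3CCCC3)c2nc1C#N` gives > 50000 nM, again a limit. Among the measured compounds shown here, compound 3 `CN1CCN(CCn2c(N)c(-c3nc4ccccc4[nH]3)c3nc(C#N)c(C#N)nc32)CC1` gives 9110 nM, the only actual number.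

Compound 4 `CN1CCN(CCCn2c(N)c(-c3nc4ccccc4[nH]3)c3nc(C#N)c(C#N)nc32)CC1` differs from compound 3 by (4-methylpiperazin-1-yl)methyl in place of 4-methylpiperazin-1-yl on a saturated chain carbon, two bonds along the chain from an aromatic nitrogen. The same change reads as 2-(4-methylpiperazin-1-yl)ethyl to 3-(4-methylpiperazin-1-yl)propyl. For the measured compounds named here, no measured step changes the chain length alone. The nearest evidence is an at least 5.4-fold lower number from compound 1 to compound 3 (0.73 log units; beyond the scatter), together with an at least 5.4-fold lower number from compound 2 to compound 3 (0.73 log units; beyond the scatter). Both lie beyond the scatter, but they exchange or add the whole group rather than lengthen it. The third step, a step that the two limits leave unreadable from compound 1 to compound 2, cannot be read.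

Compound 4 keeps the 4-methylpiperazin-1-yl group, so no step beyond the scatter is expected in this assay, in either direction. The expected step is a 1.0-fold lower number from compound 3 to compound 4 (0.01 log units; within the scatter). For compound 4 the estimate is 9000 nM, with an expected range of 3000 nM to 30000 nM.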

Compound 4, half-maximal inhibitory concentration: 4520 nM
Estimate against measurement, compound 4: 2.0-fold (0.30 log units) above; measured number inside the range.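

In this assay, the length of the chain can now be read on its own: going from 2-(4-methylpiperazin-1-yl)ethyl to 3-(4-methylpiperazin-1-yl)propyl gives a 2.0-fold lower number from compound 3 to compound 4 (0.30 log units; within the scatter), so this added chain carbon does not move the read-out beyond the scatter. The propyl chain also keeps the separation from the two compounds without the 4-methylpiperazin-1-yl group, with an at least 11-fold lower number from compound 2 to compound 4 (1.04 log units; beyond the scatter) and an at least 11-fold lower number from compound 1 to compound 4 (1.04 log units; beyond the scatter). Both of these steps are open-ended, as each starts from a limit of the assay and not from a number: the limit of > 50000 nM in this assay, at which 2 of the 4 values shown sit.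

The compounds shown leave open whether a longer chain, such as butyl, carrying the same 4-methylpiperazin-1-yl group would stay at this level. They also leave open how a morpholin-4-yl or dimethylamino group would read on the propyl chain.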